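Swapping the pyridyl hydrazone arm on a ribose-bearing core

This account rests on a few compounds, and the source may have more. Where it says the series, first, only, none or still open, it means among the compounds named here.

Compound 1 `CC(=O)Nc1ccc(/C=N/Nc2nc(N)c3ncn([C@@H]4O[C@H](CO)[C@@H](O)[C@H]4O)c3n2)cc1` carries a 4-acetamidophenyl group on the hydrazone carbon. In an assay on CHO-K1 cells for displacement of a labelled ligand from adenosine receptor A1 (Homo sapiens), read by scintillation counting, with a stated time of 60 min (a lower number here means a stronger inhibitor, a higher number a weaker inhibitor), compound 1 gives only a limit, > 10000 nM. Compound 2 `COc1ccc(/C=N/Nc2nc(N)c3ncn([C@@H]4O[C@H](CO)[C@@H](O)[C@H]4O)c3n2)cn1` bears a 6-methoxypyridin-3-yl group at the same place, and in this assay compound 2 gives 2.6 nM. That single change brings an at least 3800-fold lower number from compound 1 to compound 2 (3.58 log units; beyond the scatter). Within the data shown here, compound 2 therefore holds the only number reported in this assay; the other value is a limit (the limit of > 10000 nM in this assay, at which 1 of the 2 values shown sits). Compound 3 `Nc1nc(N/N=C/c2ccc(Br)cn2)nc2c1ncn2[C@@H]1O[C@H](CO)[C@@H](O)[C@H]1O` has not yet been measured there. It differs from compound 2 in one place: 5-bromopyridin-2-yl in place of 6-methoxypyridin-3-yl on a carbon with a double bond to nitrogen. Among the measured compounds shown here, only one measured step touches this position, an at least 3800-fold lower number from compound 1 to compound 2 (3.58 log units; beyond the scatter), and it shows that the aryl group on the hydrazone carbon can shift the result across the whole span seen so far. Compound 3 keeps a pyridine ring, so a step far smaller than an at least 3800-fold lower number from compound 1 to compound 2 (3.58 log units; beyond the scatter) is expected, toward a somewhat higher number: a 5.8-fold higher number from compound 2 to compound 3 (0.76 log units; beyond the scatter). Compound 3 is thus estimated at 15 nM, within 2 nM to 150 nM.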

Compound 3, inhibition constant: 4.7 nM
Compound 3: middle estimate off by 3.2-fold (0.50 log units), on the high side; the measured number falls inside the stated range.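

In this assay, the new result adds a second pyridine-bearing group at this place: a 1.8-fold higher number from compound 2 to compound 3 (0.26 log units; within the scatter). Exchanging 6-methoxypyridin-3-yl for 5-bromopyridin-2-yl on the carbon with a double bond to nitrogen thus changes the ring's attachment and its substituent, yet the two values remain within the scatter of each other. The other step, an at least 2100-fold lower number from compound 1 to compound 3 (3.32 log units; beyond the scatter), shows that the large gap seen with compound 2 is not confined to the methoxy-bearing group, although compound 1 stays a limit and not a number: the limit of > 10000 nM in this assay, at which 1 of the 3 values shown sits.

The compounds shown change the ring and its substituent together, leaving open whether the ring nitrogen or the acetamide separates compound 1 from compound 2 and compound 3, a question that a methoxyphenyl or bromophenyl group at this carbon would help to settle. Also open, from the compounds shown here alone, is how far this result extends beyond these two pyridine groups, for instance to a pyridine bearing an amine or a carboxylic acid, or to one with a longer alkoxy chain in place of methoxy.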